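A few compounds are considered here, and "the series" means these few. Any claim that something is new, unique, unknown or untested is made for them only; others in the source may bear on it.

Measured so far in a functional assay on MCF7 cells (Homo sapiens) for cytotoxicity, read by MTT assay, with a stated time of 48 h; a lower number here means a stronger inhibitor, a higher number a weaker inhibitor:
Compound 1 `COc1cc(-c2nnc3n2NC(c2cccs2)C(C(=O)c2ccc(C)cc2)S3)cc(OC)c1OC` gives 28400 nM.
Compound 2 `COc1cc(-c2nnc3n2NC(c2ccco2)C(C(=O)c2ccc(C)cc2)S3)cc(OC)c1OC` gives only a limit, > 100000 nM.

Compound 2 thus sits at the assay limit (the limit of > 100000 nM in this assay, at which 1 of the 2 values shown sits), the weaker end of the two values shown; the step of an at least 3.5-fold higher number from compound 1 to compound 2 (0.54 log units; beyond the scatter) is beyond the scatter. Compound 3 `COc1cccc(C(=O)C2Sc3nnc(-c4cc(OC)c(OC)c(OC)c4)n3NC2c2ccco2)c1` differs from compound 2 by 3-methoxyphenyl in place of 4-methylphenyl on a carbonyl carbon. Among the measured compounds shown here, no measured step touches the carbonyl aryl group, so nothing here bears on this change, and no step beyond the scatter is expected in this assay. Compound 3 is estimated at 100000 nM, range 30000 nM to 300000 nM. The expected step of a number no higher from compound 2 to compound 3 (the limit leaves the size open) is essentially flat, with a limit again likely.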

Compound 3, half-maximal inhibitory concentration: > 100000 nM
Compound 3 ended at the assay's limit; the forecaster's own chance of this, stated with the estimate: 70%; the middle value lies on the limit itself.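

No step can be read between compound 2 and compound 3, since each value is a limit and not a number: the limit of > 100000 nM in this assay, at which 2 of the 3 values shown sit.
On these data alone, whether 3-methoxyphenyl in place of 4-methylphenyl on a carbonyl carbon changes the number at all remains open.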